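A Benzyl Group Swap on Compound 2

The source may hold more compounds than are shown below. What is called first, only, known or untested is meant among the compounds shown, and "the series" means these compounds.

Compound 1 (`Cc1cc(Nc2nc(NCc3ccc(F)cc3F)nc3[nH]ncc23)n[nH]1`): 670 nM
Compound 2 (`Cc1cc(Nc2nc(NCc3ccc(Cl)cc3)nc3c2cnn3C2CCOCC2)n[nH]1`): 1550 nM

Both compounds were tested in a functional assay on MCF7 cells (Homo sapiens) for inhibition, read by MTT assay, with a stated time of 5 days (a higher number here means a weaker inhibitor, a lower number a stronger inhibitor), where compound 2 gives 1550 nM as the higher of the two numbers, and its gap to compound 1 lies beyond the scatter. Compound 3 (`Cc1cc(Nc2nc(NCc3ccc(F)cc3F)nc3c2cnn3C2CCOCC2)n[nH]1`) has not yet been measured. It keeps the core of compound 2 but has 2,4-difluorophenyl in place of 4-chlorophenyl on a saturated chain carbon bound to a nitrogen on an aromatic ring. Going by the values given here, no measured pair shows this change alone. Compound 1 at 670 nM carries the same 2,4-difluorobenzyl group but also differs from compound 2 elsewhere, so it offers only a weak hint of a lower number. The expected change is a 1.3-fold lower number from compound 2 to compound 3 (0.13 log units; within the scatter) which is a slight fall that stays within the scatter. Compound 3 is estimated at 1150 nM with an expected range of 450 nM to 3000 nM until a measurement is available.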

Compound 3, half-maximal inhibitory concentration: 360 nM
For compound 3 the middle estimate is 3.2-fold (0.50 log units) above the measured one; measured number below the stated range.
By their numbers in this assay, from the lowest: compounds 3 and 1 (each within the scatter of the next); then compound 2.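

In this assay, replacing 4-chlorophenyl with 2,4-difluorophenyl on a saturated chain carbon bound to a nitrogen on an aromatic ring can now be read as a change in one place: a 4.3-fold lower number from compound 2 to compound 3 (0.63 log units; beyond the scatter), so the number does respond to this swap when the rest of the molecule stays fixed. Compound 1 and compound 3 also differ in one place, oxan-4-yl in place of hydrogen on an aromatic nitrogen, and a 1.9-fold lower number from compound 1 to compound 3 (0.27 log units; within the scatter) shows no clear effect of that change alongside 2,4-difluorophenyl. Nothing measured here accounts for either step.

A 4-fluorophenyl or 2-fluorophenyl group in the same place would show whether one fluorine is enough for this step or both are needed. On these data alone, whether a cyclopentyl or methyl group could replace oxan-4-yl without moving the number also remains open.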